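A few compounds are considered here, and "the series" means these few. Any claim that something is new, unique, unknown or untested is made for them only; others in the source may bear on it.

Of the compounds shown here, two of a shared core have been measured. Compound 1 `COc1cc(/C=C/C(=O)c2cccc(-n3cc(-c4ccc(Cl)cc4)[nH]c3=O)c2)ccc1O` gives 3170 nM in a functional assay on SNB-19 cells (Homo sapiens) for inhibition; on this read-out higher numbers stand for weaker inhibition of growth and lower numbers for stronger inhibition of growth. Compound 2 `COc1ccc(-c2cn(-c3cccc(C(=O)/C=C/c4cc(OC)c(OC)c(OC)c4)c3)c(=O)[nH]2)cc1` gives 4380 nM in this assay, and on these two numbers compound 2 stands alongside compound 1, the two values lying within the scatter of one another, so nothing separates them.

Compound 3 `COc1ccc(-c2cn(-c3cccc(C(=O)/C=C/c4ccc(O)c(OC)c4)c3)c(=O)[nH]2)cc1` has not yet been measured in this assay. It differs from compound 2 in one place: 4-hydroxy-3-methoxyphenyl in place of 3,4,5-trimethoxyphenyl on a double-bonded chain carbon bound to a double-bonded chain carbon. For the measured compounds named here, no step between measured compounds is available for this change, but compound 1 carries the same 4-hydroxy-3-methoxyphenyl and sits within the scatter of compound 2, which gives no ground to expect much of a move.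

The step from compound 2 to compound 3 is therefore expected to be a 1.3-fold lower number from compound 2 to compound 3 (0.10 log units; within the scatter), a change not beyond the scatter. Compound 3 is estimated at 3500 nM in this assay, within a range from 1500 nM to 8000 nM.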

Compound 3, concentration for 50% growth inhibition: 5840 nM
For compound 3 the middle estimate is 1.7-fold (0.22 log units) below the measured one, within the range that was stated.
By their numbers in this assay, from the lowest: compounds 1, 2 and 3 (each within the scatter of the next).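

In this assay the change of 3,4,5-trimethoxyphenyl to 4-hydroxy-3-methoxyphenyl on a double-bonded chain carbon bound to a double-bonded chain carbon gives a 1.3-fold higher number from compound 2 to compound 3 (0.12 log units; within the scatter) and so now has a direct reading, which shows no move beyond the scatter at this position. The result also gives a reading at a second place, where methoxy in place of chloro on an aromatic carbon gives a 1.8-fold higher number from compound 1 to compound 3 (0.27 log units; within the scatter) and again stays within the scatter. No measurement bears on why either step is as small as it is.

On these data alone, both groups compared at the chain carbon are substituted phenyl rings, so it stays open whether a ring carrying an amine or a carboxylic acid would give a larger step. As far as these compounds go, it is also open whether anything other than chloro or methoxy on the aromatic carbon, such as a longer alkoxy chain, would move the number beyond the scatter.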